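Varying the para substituent on the pendant phenyl

The source may hold more compounds than are shown below. What is called first, only, known or untested is meant among the compounds shown, and "the series" means these compounds.

Three analogues sharing one core have been measured in an assay on isolated protein for inhibition of ubiquitin carboxyl-terminal hydrolase 7 (Homo sapiens), with stated times of 30 min and 2 h; on this read-out lower numbers stand for stronger inhibition and higher numbers for weaker inhibition. Compound 1 `Cn1nc2c(=O)n(CC3(O)CCN(Cc4ccc(-c5ccco5)cc4Cl)CC3)cnc2c1-c1ccc(C2(N)CC2)cc1` gives 66.1 nM; compound 2 `Cn1nc2c(=O)n(CC3(O)CCN(Cc4ccc(-c5ccco5)cc4Cl)CC3)cnc2c1-c1ccc(C(=N)N)cc1` gives 87.5 nM; compound 3 `Cn1nc2c(=O)n(CC3(O)CCN(Cc4ccc(-c5ccco5)cc4Cl)CC3)cnc2c1-c1ccc(F)cc1` gives 64.5 nM. Compound 3 holds the lowest of the three numbers, but the gaps are small: a 1.0-fold lower number from compound 1 to compound 3 (0.01 log units; within the scatter) and a 1.4-fold lower number from compound 2 to compound 3 (0.13 log units; within the scatter), both within the scatter, as is a 1.3-fold higher number from compound 1 to compound 2 (0.12 log units; within the scatter). Three quite different groups at this position therefore read as one.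

Compound 4 `CC(=O)NCc1ccc(-c2c3ncn(CC4(O)CCN(Cc5ccc(-c6ccco6)cc5Cl)CC4)c(=O)c3nn2C)cc1` continues at the same place: acetamidomethyl in place of fluoro on an aromatic carbon. The two steps that bear on it, from compound 1 and from compound 2 to compound 3, each replaced a group at this same aromatic carbon and each stayed within the scatter, so no step beyond the scatter is expected in this assay here either, in either direction. Compound 4 is estimated at 70 nM with a range of 30 nM to 165 nM; the expected step is a 1.1-fold higher number from compound 3 to compound 4 (0.04 log units; within the scatter), a flat reading pending measurement.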

Compound 4, half-maximal inhibitory concentration: 46.1 nM
Compound 4: the middle estimate sits 1.5-fold (0.18 log units) above what was measured, and the stated range covers the measured number.
By their numbers in this assay, from the lowest: compounds 4, 3, 1 and 2 (each within the scatter of the next).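

In this assay this position on the aromatic carbon also accepts acetamidomethyl, which brings more heavy atoms than any group before it as well as a hydrogen-bond donor and acceptor, and no step beyond the scatter results: a 1.4-fold lower number from compound 3 to compound 4 (0.15 log units; within the scatter) and a 1.4-fold lower number from compound 1 to compound 4 (0.16 log units; within the scatter). The widest gap among the four compounds, a 1.9-fold lower number from compound 2 to compound 4 (0.28 log units; within the scatter), also stays within the scatter, so the flat reading now extends to a chain carrying an amide. Nothing at hand accounts for this flat reading.

Still open, as far as these compounds go, is whether a carboxylic acid, a longer amide chain or a group bearing a ring at this position would give a step beyond the scatter. The compounds shown also leave open whether the flat reading would hold with a group other than the 4-substituted phenyl's present partners elsewhere on the shared core.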